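The source may report more compounds than this note shows. Statements on the series, on what has been measured and on what is new or still open speak of the compounds shown alone.

Going by the values given here, in a functional assay on DU-145 cells (Homo sapiens) for inhibition, read by trypan blue exclusion, with a stated time of 72 h (a higher number here means a weaker inhibitor, a lower number a stronger inhibitor), compound 2 (`Cn1c(=O)c(S(=O)(=O)c2ccc(Cl)cc2)cc2cnc(Nc3cccc4[nH]ccc34)nc21`) gives 5000 nM, the lower of the two numbers so far and beyond the scatter from compound 1 (`Cc1ccc(S(=O)(=O)c2cc3cnc(Nc4cnc5[nH]ccc5c4)nc3n(C)c2=O)cc1`), which gives 25000 nM. Compound 3 (`Cn1c(=O)c(S(=O)(=O)c2ccc(Cl)cc2)cc2cnc(Nc3cnc4[nH]ccc4c3)nc21`) differs from compound 2 by one change: a group of 9 heavy atoms (7 carbon, 2 nitrogen; one five-membered aromatic ring with 1 hetero atom, one six-membered aromatic ring with 1 hetero atom) in place of a group of 9 heavy atoms (8 carbon, 1 nitrogen; one five-membered aromatic ring with 1 hetero atom, one six-membered aromatic ring of carbon only), on a nitrogen on an aromatic ring. Among the compounds with values here, no measured step isolates this change. The entering group also stands in compound 1, the weaker inhibitor at 25000 nM, so some loss is expected. The expected change is a 2.4-fold higher number from compound 2 to compound 3 (0.38 log units; beyond the scatter), towards a weaker inhibitor and slightly beyond the scatter. For compound 3 the estimated value is 12000 nM, with an expected range from 4000 nM to 30000 nM.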

Compound 3, half-maximal inhibitory concentration: 5000 nM
Compound 3: middle estimate off by 2.4-fold (0.38 log units), on the high side; measured number inside the range.
By their numbers in this assay, from the lowest: compounds 2 and 3 (each within the scatter of the next); then compound 1.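

Compound 3 shows that the group entering on this nitrogen on an aromatic ring costs nothing against 1H-indol-4-yl in this assay when chloro is present, with no change at the digits printed from compound 2 to compound 3 (within the scatter) and no loss of the kind compound 1 suggested. Going by these compounds alone, with that group held fixed, a 5.0-fold lower number from compound 1 to compound 3 (0.70 log units; beyond the scatter) follows chloro in place of methyl on an aromatic carbon, the only single-place step here beyond the scatter. Open, on these data alone, is whether methoxy or trifluoromethyl on that aromatic carbon would lower the number further. No measurement available explains either step.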